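Compound 2 loses its chloro

This account rests on a few compounds, and the source may have more. Where it says the series, first, only, none or still open, it means among the compounds named here.

In a physicochemical assay for solubility, read by nephelometry, measured as kinetic solubility, at pH 6.5, tested at 10 mg/mL (on this read-out higher numbers stand for higher solubility and lower numbers for lower solubility), compound 1 (`Cc1ccccc1C(=O)Nc1cc(Cl)ccn1`) gives 12.5 ug/mL and compound 2 (`Cc1c(F)cccc1C(=O)Nc1cc(Cl)ccn1`) gives 12.5 ug/mL, the same reading. Among the compounds with values here, the one measured step shows no change at the digits printed from compound 1 to compound 2 (within the scatter), but it concerns a fluoro and not a chloro, so it gives little guidance here. Compound 4 (`Cc1c(F)cccc1C(=O)Nc1ccccn1`) differs from compound 2 by hydrogen in place of chloro on an aromatic carbon, on an aromatic carbon opposite the ring nitrogen. Compound 3 (`Cc1cc(Br)ccc1C(=O)Nc1ccccn1`), which carries no chloro, gives > 100 ug/mL, a limit of this assay, and this alone points to an expected rise of uncertain size. The step expected is a 4.8-fold higher number from compound 2 to compound 4 (0.68 log units; beyond the scatter). Compound 4 is estimated at 60 ug/mL, with an expected range of 25 ug/mL to 150 ug/mL.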

Compound 4, solubility: 25 ug/mL
The estimate for compound 4 lay 2.4-fold (0.38 log units) above the measured number, within the range that was stated.
By their numbers in this assay, from the lowest: compounds 1, 2 and 4 (each within the scatter of the next). At a limit, above all of these: compound 3.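

At the aromatic carbon opposite the ring nitrogen, hydrogen in place of chloro gives in this assay a 2.0-fold higher number from compound 2 to compound 4 (0.30 log units; within the scatter). Within the data shown here, this is the first reading at this position, and it shows that losing this one chlorine atom leaves compound 4 within the scatter of compound 2. Nothing measured here gives a reason for this reading.

From the compounds shown here alone, it remains open whether an amine, a methoxy group or a carboxylic acid at this position would move the reading beyond the scatter. Going by these compounds, whether the same change reads alike without the fluoro also remains open.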